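Moving the ether from one ring position to another in compound 1

This account rests on a few compounds, and the source may have more. Where it says the series, first, only, none or still open, it means among the compounds named here.

Compound 1 `COc1ccccc1Nc1nc(SCc2ccc(C(F)(F)F)cc2)nc2ccccc12` sits at the top of the numbers seen so far. In a functional assay on MCF7 cells (Homo sapiens) for cytotoxicity, read by MTT assay, with a stated time of 72 h (a higher number here means a weaker inhibitor, a lower number a stronger inhibitor), compound 1 gives > 50000 nM, which is a limit of the assay and not a measured number. Compound 2 `FC(F)(F)c1ccc(CSc2nc(Nc3ccc(Cl)cc3)c3ccccc3n2)cc1` gives 21500 nM in this assay, and compound 3 `O=[N+]([O-])c1ccc(Nc2nc(SCc3ccc(C(F)(F)F)cc3)nc3ccccc23)cc1` gives 17900 nM. The two steps that leave the 2-methoxyphenyl group are an at least 2.3-fold lower number from compound 1 to compound 2 (0.36 log units; beyond the scatter) and an at least 2.7-fold lower number from compound 1 to compound 3 (0.44 log units; beyond the scatter), both resting on (the limit of > 50000 nM in this assay, at which 1 of the 3 values shown sits); between the two 4-substituted rings there is only a 1.2-fold lower number from compound 2 to compound 3 (0.08 log units; within the scatter).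

Compound 4 `CCOc1ccc(Nc2nc(SCc3ccc(C(F)(F)F)cc3)nc3ccccc23)cc1` has not yet been measured. It differs from compound 1 by 4-ethoxyphenyl in place of 2-methoxyphenyl on a nitrogen on an aromatic ring. The two measured steps away from the 2-methoxyphenyl group both point the same way, so a lower number is expected in this assay, of roughly the size seen with compounds 2 and 3, though a further limit cannot be ruled out. For compound 4 the estimate is 25000 nM, between 10000 nM and 60000 nM, which would be a step of an at least 2.0-fold lower number from compound 1 to compound 4 (0.30 log units; that floor lies within the scatter).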

Compound 4, half-maximal inhibitory concentration: > 50000 nM
Compound 4 ended at the assay's limit; the forecaster's own chance of this, stated with the estimate: 35%; middle value at least 2.0-fold (0.30 log units) from the limit.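

In this assay compound 4 gives > 50000 nM as a limit of the assay and not as a measured number, which shows that leaving the 2-methoxyphenyl group does not by itself lower the number. The outcome now depends on the group the new ring carries, with an at least 2.7-fold higher number from compound 3 to compound 4 (0.44 log units; beyond the scatter) for ethoxy in place of nitro and an at least 2.3-fold higher number from compound 2 to compound 4 (0.36 log units; beyond the scatter) for ethoxy in place of chloro. The step between compound 1 and compound 4 cannot be read, and both readable steps rest on the same ceiling: the limit of > 50000 nM in this assay, at which 2 of the 4 values shown sit.

The compounds shown leave open how 4-methoxyphenyl would behave, which would separate the place of the ether from the length of its chain. Also open, from the compounds shown here alone, is whether a ring carrying an amine or a carboxylic acid would give a measurable value.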